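This account rests on a few compounds, and the source may have more. Where it says the series, first, only, none or still open, it means among the compounds named here.

Measured compounds:
compound 1, `CCOc1ncccc1-c1c(C)nn(-c2nc(-c3ccc(Cl)c(Cl)c3)c(SC(C)C)s2)c1C(=O)O` — 11000 nM
compound 2, `COC(=O)c1c(Cc2ccccc2[N+](=O)[O-])c(C)nn1-c1nc(-c2ccc(Cl)c(Cl)c2)c(SC(C)C)s1` — 93000 nM
compound 3, `Cc1c(-c2cc(Cl)cc(Cl)c2)c(C(=O)O)nn1-c1nc(-c2ccc3nccn3c2)c(SC(C)C)s1` — "not active" (no number reported)

In a functional assay on BJAB cells (Homo sapiens) for antiproliferative activity, with a stated time of 4 days (on this read-out lower numbers stand for an effect already at smaller amounts and higher numbers for an effect only at larger amounts of compound), compound 1 gives 11000 nM and stands at the lowest of the two numbers in the set. Compound 2 gives 93000 nM, a gap beyond the usual scatter, so compound 1 is the stronger of the two numbered entries. Compound 3 contributes no single number. Going by the values given here, with only two numbers, neither of them separated from compound 1 by a single change, no step between measured compounds can be read, and no pattern is claimed.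

Compound 4, `COc1cc(Cl)cc(-c2c(C)nn(-c3nc(-c4ccc(Cl)c(Cl)c4)c(SC(C)C)s3)c2C(=O)O)c1`, is not yet measured. Relative to compound 1 it differs at one place: 3-chloro-5-methoxyphenyl in place of 2-ethoxypyridin-3-yl on an aromatic carbon. The shared core and the remaining substituents are kept.

Among the compounds with values here, no measured pair informs the size of this change. The expected outcome in this assay is a step from compound 1 to compound 4 of a 1.3-fold higher number from compound 1 to compound 4 (0.10 log units; within the scatter), that is, no change beyond the scatter, since compound 1 with 11000 nM is the only anchor and the exchanged group is of matching size. Compound 4 is estimated at 14000 nM, with a range from 4000 nM to 50000 nM.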

Compound 4, half-maximal effective concentration: 760 nM
Compound 4: middle estimate off by 18-fold (1.27 log units), on the high side; the measured number lies below the stated range.
By their numbers in this assay, from the lowest: compound 4; then compound 1; then compound 2.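

Exchanging 2-ethoxypyridin-3-yl for 3-chloro-5-methoxyphenyl on this aromatic carbon, next to the ring atom that bears a carboxy group, gives a 14-fold lower number from compound 1 to compound 4 (1.16 log units; beyond the scatter) in this assay. Going by these compounds alone, this position therefore responds strongly to the identity of its aromatic substituent, which the earlier compounds could not show, as no step between measured compounds was available. The two groups have the same heavy-atom count, so the step occurs without a change in that count, while the ring nitrogen and ethoxy group give way to a chlorine and a methoxy group, and no available measurement bears on the cause of this step.

Within the data shown here, the single exchange alters the ring and both of its substituents together, so the share of each in the step remains unresolved. Simple phenyl, 3-chlorophenyl and 3-methoxyphenyl at this place would help separate those contributions, while a 3-amino-5-chlorophenyl group would test whether an amine can stand in place of the methoxy group.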